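This account rests on a few compounds, and the source may have more. Where it says the series, first, only, none or still open, it means among the compounds named here.

Among the three measured analogues, compound 3 `CCN(CC)CCn1cnnc1-c1cc(Oc2ccc(NC(=O)Nc3ccc(F)c(Cl)c3)cc2F)ccn1` gives the highest number in a functional assay on MDA-MB-231 cells (Homo sapiens) for antiproliferative activity, read by MTT assay, with a stated time of 72 h (on this read-out lower numbers stand for stronger inhibition and higher numbers for weaker inhibition), namely 34000 nM. Compound 1 `CCN(CC)CCn1cnnc1-c1cc(Oc2ccc(NC(=O)Nc3ccc(Cl)c(C(F)(F)F)c3)cc2F)ccn1` gives 1540 nM and compound 2 `CCN(CC)CCn1cnnc1-c1cc(Oc2ccc(NC(=O)Nc3ccccc3C(F)(F)F)cc2F)ccn1` gives 11600 nM, so the step of a 22-fold higher number from compound 1 to compound 3 (1.34 log units; beyond the scatter) is large and the step of a 2.9-fold higher number from compound 2 to compound 3 (0.47 log units; beyond the scatter) is modest, both beyond the scatter. Compound 4 `CCN(CC)CCn1cnnc1-c1cc(Oc2ccc(NC(=O)Nc3ccc(Cl)cc3Cl)cc2F)ccn1` differs from compound 3 by 2,4-dichlorophenyl in place of 3-chloro-4-fluorophenyl on an amide-type nitrogen. Both measured steps onto compound 3 went upward, and the aryl group of compound 4 carries two halogens like that of compound 1 and a substituent pattern recalling compound 2, so a modest downward step of about a 4.9-fold lower number from compound 3 to compound 4 (0.69 log units; beyond the scatter) is expected. Compound 4 is therefore estimated at 7000 nM in this assay, within a range from 2000 nM to 25000 nM.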

Compound 4, half-maximal inhibitory concentration: 1790 nM
Compound 4: middle estimate off by 3.9-fold (0.59 log units), on the high side; the whole stated range lies above it.
By their numbers in this assay, from the lowest: compounds 1 and 4 (each within the scatter of the next); then compound 2; then compound 3.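

In this assay, 2,4-dichlorophenyl on the amide-type nitrogen cannot be told apart from the 4-chloro-3-(trifluoromethyl)phenyl of compound 1 (a 1.2-fold higher number from compound 1 to compound 4 (0.07 log units; within the scatter)), so among these compounds a trifluoromethyl group is not needed for the lowest numbers. Changing only the halogens and their places on the aryl group moves the number widely (a 19-fold lower number from compound 3 to compound 4 (1.28 log units; beyond the scatter)), and 2,4-dichlorophenyl also stands apart from 2-(trifluoromethyl)phenyl (a 6.5-fold lower number from compound 2 to compound 4 (0.81 log units; beyond the scatter)). Nothing available here explains these differences. The compounds shown leave open whether a methoxy group or a nitrile on this phenyl ring would keep the number as low.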